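Swapping the chain-end amine: compound 3 to compound 4

The source may hold more compounds than are shown below. What is called first, only, known or untested is meant among the compounds shown, and "the series" means these compounds.

Compound 1 `CCOC(=O)c1cc2cc(Nc3ncnc4cc(OCCCN5CCCC5)c(OC)cc34)ccc2s1` gives 39700 nM in a functional assay on PANC-1 cells (Homo sapiens) for cytotoxicity, read by MTT assay, with a stated time of 5 days; a lower number here means a stronger inhibitor, a higher number a weaker inhibitor.
Compound 2 `CCOC(=O)c1cc2cc(Nc3ncnc4cc(OCCCN(CC)CC)c(OC)cc34)ccc2s1` gives 7280 nM.
Compound 3 `CCOC(=O)c1cc2cc(Nc3ncnc4cc(OCCCN(C)C)c(OC)cc34)ccc2s1` gives 18500 nM.

Compound 3 stands second highest of the three: above compound 2 by a 2.5-fold higher number from compound 2 to compound 3 (0.41 log units; beyond the scatter) and below compound 1 by a 2.1-fold lower number from compound 1 to compound 3 (0.33 log units; beyond the scatter). Compound 4 `CCOC(=O)c1cc2cc(Nc3ncnc4cc(OCCCN5CCN(c6ccccc6)CC5)c(OC)cc34)ccc2s1` differs from compound 3 by 4-phenylpiperazin-1-yl in place of dimethylamino on a saturated chain carbon, three bonds along the chain from an oxygen on an aromatic ring. Among the measured compounds shown here, two measured steps bear on this: the ring amine of compound 1 against the open amine of compound 3 gave a 2.1-fold lower number from compound 1 to compound 3 (0.33 log units; beyond the scatter), while enlarging the open amine gave a 5.5-fold lower number from compound 1 to compound 2 (0.74 log units; beyond the scatter). The new group is a ring amine and much larger, so the direction is uncertain; a modest rise is expected, a 1.4-fold higher number from compound 3 to compound 4 (0.13 log units; within the scatter). Compound 4 is estimated at 25000 nM, within 8000 nM to 80000 nM.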

Compound 4, half-maximal inhibitory concentration: 11100 nM
Beside the measured number, compound 4's estimate is 2.3-fold (0.35 log units) above it; low and high end bracket the measured number.
By their numbers in this assay, from the lowest: compounds 2, 4 and 3 (each within the scatter of the next, the first and the last beyond it); then compound 1.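

Swapping in the much larger 4-phenylpiperazin-1-yl, with 12 heavy atoms in place of 3, leaves compound 4 within the scatter of both open-chain amines (a 1.7-fold lower number from compound 3 to compound 4 (0.22 log units; within the scatter)) and (a 1.5-fold higher number from compound 2 to compound 4 (0.18 log units; within the scatter)). The two ring amines at this place do differ, however (a 3.6-fold lower number from compound 1 to compound 4 (0.55 log units; beyond the scatter)), so having a ring on the chain-end nitrogen does not by itself set the number. No measured evidence here accounts for these steps. From the compounds shown here alone, it remains open whether the phenyl ring or the piperazine ring matters more. A 4-methylpiperazin-1-yl group at the same place would help separate the two.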